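Cutting Back the Side Chain of Compound 3

This account rests on a few compounds, and the source may have more. Where it says the series, first, only, none or still open, it means among the compounds named here.

The series was tested in a functional assay on the whole organism (Tail, strain ICR) with Mus musculus as the target, in the tail flick test, with a stated time of 60 min, at a dose of 25 umol/kg by the oral route; on this read-out higher numbers stand for a stronger effect at the one dose given and lower numbers for a weaker effect. Within the data shown here, compound 1 `CSCC[C@H](NC(=O)CN(c1ncnc2c1ncn2C1CCCCO1)C1CC1)C(=O)OCc1ccccc1` gives 41%, and compound 2 `C[C@H](NC(=O)CN(c1ncnc2c1ncn2C1CCCCO1)C1CC1)C(=O)OCc1ccccc1` gives 53%; the one recorded step, a number 12 percentage points higher from compound 1 to compound 2 (beyond the scatter), is the only measured guide to replacing a side chain on this chain carbon by hydrogen. Compound 3 `O=C(O)CC[C@H](NC(=O)CN(c1nc(Cl)nc2[nH]cnc12)C1CC1)C(=O)O` gives 33.3% in this assay; it stands lowest of the three numbers, within the scatter of compound 1 and beyond the scatter of compound 2. Compound 4 `O=C(O)CNC(=O)CN(c1nc(Cl)nc2[nH]cnc12)C1CC1` has not been measured. It differs from compound 3 in one place: hydrogen in place of 2-carboxyethyl on a saturated chain carbon bound to an amide-type nitrogen and a carbonyl carbon. The step from compound 1 to compound 2 bears on it, as there too a side chain was removed from the chain carbon, though the shared core and the ester end differ between the two pairs. Because a number 12 percentage points higher from compound 1 to compound 2 (beyond the scatter) was modest, a rise of similar size, or none beyond the scatter, is expected. The estimate for compound 4 in this assay is 40%, between 25% and 58%. That means an expected step of a number 6.7 percentage points higher from compound 3 to compound 4 (within the scatter).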

Compound 4, a percentage reported as activity, at one dose (the size of the read-out at that dose, not a potency): 38.9%
The estimate for compound 4 lay 1.1 percentage points above the measured number; low and high end bracket the measured number.
By their numbers in this assay, from the lowest: compounds 3, 4 and 1 (each within the scatter of the next); then compound 2.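

In this assay, taking 2-carboxyethyl off the saturated chain carbon bound to an amide-type nitrogen and a carbonyl carbon gives a number 5.6 percentage points higher from compound 3 to compound 4 (within the scatter), so on this core and with free carboxylic acid ends, the side chain can be lost without a change beyond the scatter. The earlier step, a number 12 percentage points higher from compound 1 to compound 2 (beyond the scatter), came from a different pair with a benzyl ester end, and its rise beyond the scatter is not repeated in this pair. The data shown offer no measurement that accounts for this outcome.

On the core of compound 3, this chain carbon is described only by 2-carboxyethyl and hydrogen. On these data alone, how a methyl group, a longer chain or an amine at this place would read in this test remains open, as does the effect of a benzyl ester end on compound 4.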